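Swapping the amide's pyridine for a difluorophenyl ring

The compounds below may be only part of what the source reports. "The series", "measured", "known", "first", "only" and "open" are said of these compounds alone.

Compound 1 `CC(C)n1ncc2c(C(=O)Nc3cccnc3)cc(-c3cccs3)nc21` has been tested for how much of it cells tolerate in an ADME assay on LLC-MK2 cells (Macaca mulatta) for cytotoxicity, read by spectrophotometry and crystal violet staining, with a stated time of 4 days; a higher number here means that more compound is tolerated, a lower number that less compound is tolerated. For compound 1 the result is only a limit, > 200000 nM, one of the values that sit at the edge of what the measurement reports (the limit of > 200000 nM in this assay, at which 1 of the 3 values shown sits). Two related compounds carry real numbers. Compound 3 `CC(C)n1ncc2c(C(=O)Nc3cccnc3)cc(-c3ccsc3)nc21` gives 37000 nM in this assay, and the step of an at least 5.4-fold lower number from compound 1 to compound 3 (0.73 log units; beyond the scatter) turns on the thiophene, not the amide end of the molecule. Compound 2 `CC(C)n1ncc2c(C(=O)Nc3ccccn3)cc(C3CC3)nc21` gives 25000 nM in this assay; it differs from compound 1 in two places at once, so its value only shows that compounds sharing this core can be less well tolerated.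

Compound 4 `CC(C)n1ncc2c(C(=O)Nc3c(F)cccc3F)cc(-c3cccs3)nc21` has not been measured. It differs from compound 1 in a single place: 2,6-difluorophenyl in place of pyridin-3-yl on an amide-type nitrogen. Going by the values given here, no measured step alters the group on the amide-type nitrogen, so there is no direct guide to the size of this step, and since compound 1 already sits at the limit, only a move toward a lower number could show up. For compound 4 the expected value in this assay is 100000 nM, within 30000 nM to 200000 nM. That estimate corresponds to an expected step of an at least 2.0-fold lower number from compound 1 to compound 4 (0.30 log units; that floor lies within the scatter).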

Compound 4, half-maximal cytotoxic concentration: > 200000 nM
Compound 4 was reported as a limit; the forecaster's own chance of this, stated with the estimate: 40%; middle value at least 2.0-fold (0.30 log units) from the limit.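

Compound 1 and compound 4 both stand at a limit rather than at a real number, so no step between them can be read: the limit of > 200000 nM in this assay, at which 2 of the 4 values shown sit.

The compounds shown leave open whether 2,6-difluorophenyl in place of pyridin-3-yl on the amide-type nitrogen changes how much compound the cells tolerate in this assay.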